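The source may hold more compounds than are shown below. What is called first, only, known or untested is meant among the compounds shown, and "the series" means these compounds.

In a functional assay on MDA-MB-231 cells (Homo sapiens) for cytotoxicity, read by MTT assay, with a stated time of 48 h (on this read-out lower numbers stand for stronger inhibition and higher numbers for weaker inhibition), compound 1 `O=C(NCCCCC(c1ccc(F)cc1)c1ccc(F)cc1)Nc1cccc([N+](=O)[O-])c1` gives 3790 nM. Compound 3 `CC(=O)Nc1cc(NC(=O)NCCCCC(c2ccc(F)cc2)c2ccc(F)cc2)ccc1Cl` gives 9120 nM. Compound 2 `Cc1cccc(NC(=O)NCCCCC(c2ccc(F)cc2)c2ccc(F)cc2)c1` gives > 20000 nM, which is a limit and not a number. Compound 2 therefore stands at the limit of > 20000 nM in this assay, at which 1 of the 3 values shown sits, so any step away from it is known only in part.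

Compound 4 `O=C(NCCCCC(c1ccc(F)cc1)c1ccc(F)cc1)c1ccc(Cl)c(C(F)(F)F)c1` differs from compound 2 on a carbonyl carbon, with 4-chloro-3-(trifluoromethyl)phenyl in place of (3-methylphenyl)amino on a carbonyl carbon.

Among the compounds with values here, no measured step makes this exchange, so the evidence is indirect. The nearest guides are the changes to the aromatic group on the amide-type nitrogen. Replacing nitro with methyl on an aromatic carbon gave an at least 5.2-fold higher number from compound 1 to compound 2 (0.72 log units; beyond the scatter). Replacing 3-methylphenyl with 3-acetamido-4-chlorophenyl gave an at least 2.1-fold lower number from compound 2 to compound 3 (0.34 log units; beyond the scatter). Replacing 3-nitrophenyl with 3-acetamido-4-chlorophenyl gave a 2.4-fold higher number from compound 1 to compound 3 (0.38 log units; beyond the scatter). Both measured steps away from the 3-methylphenyl group of compound 2 therefore end at lower numbers, although these are only two cases.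

A modest move towards lower numbers in this assay is expected, though a result at the limit remains possible. The expected change is an at least 2.8-fold lower number from compound 2 to compound 4 (0.45 log units; beyond the scatter). For compound 4 the estimate is 7000 nM, with an expected range of 2500 nM to 20000 nM.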

Compound 4, half-maximal inhibitory concentration: 11700 nM
Compound 4: middle estimate off by 1.7-fold (0.22 log units), on the low side; measured number inside the range.
By their numbers in this assay, from the lowest: compound 1; then compounds 3 and 4 (each within the scatter of the next). At a limit, above all of these: compound 2.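

Compounds 1, 2 and 3 all carry an aromatic group joined through an amino nitrogen at this carbonyl carbon. Compound 4 shows that 4-chloro-3-(trifluoromethyl)phenyl can take that place, without the hydrogen-bond donor of (3-methylphenyl)amino, and still give a measurable number in this assay. The exchange gives an at least 1.7-fold lower number from compound 2 to compound 4 (0.23 log units; that floor lies within the scatter), so no real gain is established and the true size of the step stays unknown: the limit of > 20000 nM in this assay, at which 1 of the 4 values shown sits.

The other readable step, a 3.1-fold higher number from compound 1 to compound 4 (0.49 log units; beyond the scatter), shows that the exchange does not reach the number set by the (3-nitrophenyl)amino group, while compound 3 and compound 4 lie within the scatter of each other.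

The amino nitrogen and the ring substituents change together in this exchange, so their contributions cannot be separated; a (4-chloro-3-(trifluoromethyl)phenyl)amino group on the same carbonyl carbon would tell them apart. Going by these compounds, it also remains open how this carbonyl-linked ring would respond to a nitro group, a carboxylic acid or an amine on the ring, or to a longer chain leading to the two fluorophenyl rings.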